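Bromo to chloro exchange across two related cores

The compounds below may be only part of what the source reports. "The series", "measured", "known", "first", "only" and "open" are said of these compounds alone.

Measured compounds:
compound 1, `COc1ccc(Br)cc1C(C)NC(=O)N(C)S(=O)(=O)c1ccc(C)cc1`, 19100 nM
compound 2, `COc1ccc(Cl)cc1C(C)NC(=O)N(C)S(=O)(=O)c1ccc(C)cc1`, 13800 nM
compound 3, `CCOc1ccc(Br)cc1C(C)NC(=O)NS(=O)(=O)c1ccc(Cl)cc1`, 171000 nM

All three were tested in a functional assay on thoracic aorta (Rattus norvegicus, strain Wistar), with a stated time of 15 min; on this read-out higher numbers stand for an effect only at larger amounts of compound and lower numbers for an effect already at smaller amounts. Compound 1 gives 19100 nM and compound 2 gives 13800 nM; the step of a 1.4-fold lower number from compound 1 to compound 2 (0.14 log units; within the scatter), and the two therefore cannot be separated by this read-out. Compound 3 gives 171000 nM, the highest number of the three, well beyond the scatter from both compound 1 and compound 2. Compound 3 and compound 1 differ in more than one place; the difference between the two cores is not broken down here.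

For the measured compounds named here, the single change from compound 1 to compound 2 is chloro in place of bromo on an aromatic carbon. The unmeasured compound 4, `CCOc1ccc(Cl)cc1C(C)NC(=O)NS(=O)(=O)c1ccc(Cl)cc1`, arises from compound 3 by the same kind of change, (chloro in place of bromo on an aromatic carbon); the two place descriptions differ in that the halogen is para to a methoxy group in the first pair and para to an ethoxy group in the second, and the rest of the two cores also differs as noted above.

Going by the values given here, since the only precedent for this exchange, a 1.4-fold lower number from compound 1 to compound 2 (0.14 log units; within the scatter), sits within the scatter, the step from compound 3 to compound 4 in this assay is expected to be of about the same size, around a 1.3-fold lower number from compound 3 to compound 4 (0.12 log units; within the scatter). Compound 4 is thus estimated at 130000 nM, with a likely range from 60000 nM to 300000 nM. Because compound 3 gives 171000 nM, the number expected for compound 4 also lies high among the compounds considered here.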

Compound 4, half-maximal effective concentration: 281000 nM
The estimate for compound 4 lay 2.2-fold (0.33 log units) below the measured number, within the range that was stated.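

In this assay, chloro in place of bromo on the aromatic carbon para to an ethoxy group gives a 1.6-fold higher number from compound 3 to compound 4 (0.22 log units; within the scatter), so this read-out does not separate the two compounds. Set beside the earlier exchange, the new step gives no sign that the outcome depends on the core, and the opposite directions of the two steps carry no weight: the same change on two cores in this assay, a 1.4-fold lower number (0.14 log units; within the scatter) from compound 1 to compound 2 and a 1.6-fold higher number (0.22 log units; within the scatter) from compound 3 to compound 4, 2.3-fold (0.36 log units) apart, within the scatter of two such steps. This supports only a limited working note: on both cores shown, the exchange produces no step that can be told from the scatter, but with only two matched pairs, it does not establish that the two halogens are interchangeable on other cores of the series or in other assays.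

The two cores differ in more than one place, and no pair shown isolates the ethoxy group from the methoxy group or resolves any other part of that difference. Also open, going by these compounds, is how the series would respond to a group other than a halogen at this aromatic carbon, such as a nitrile, a carboxylic acid or an amine, where a step beyond the scatter might or might not appear.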